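The source may hold more compounds than are shown below. What is called first, only, known or untested is meant among the compounds shown, and "the series" means these compounds.

Compounds measured so far in a functional assay on Bel-7402 cells (Homo sapiens) for inhibition, read by sulforhodamine B assay, with a stated time of 72 h, tested at 10 uM; a higher number here means more inhibition at the concentration tested (going by the name of the read-out), a lower number less inhibition:
- compound 1, `C[C@H](Nc1ncnc2[nH]cnc12)c1nn(-c2cccc(F)c2)c2cc(F)ccc12`: -17%
- compound 2, `C[C@H](Nc1ncnc2[nH]cnc12)c1nn(-c2ccccn2)c2cc(F)ccc12`: 7%

Compound 2 stands highest of the two numbers measured in this assay; its nearest neighbour is compound 1, and the step of a number 24 percentage points higher from compound 1 to compound 2 (beyond the scatter) is modest but lies beyond the scatter. Both values sit in the low range of this read-out.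

Compound 3, `C[C@H](Nc1ncnc2[nH]cnc12)c1nn(-c2cccc(S(C)(=O)=O)c2)c2cc(F)ccc12`, has not yet been measured in this assay. Its structure differs from compound 2 in one place: 3-(methylsulfonyl)phenyl in place of pyridin-2-yl on an aromatic nitrogen.

Among the measured compounds shown here, only one measured step, a number 24 percentage points higher from compound 1 to compound 2 (beyond the scatter), concerns a change of the group on this aromatic nitrogen, and it was modest. For the measured compounds named here, compound 3 carries a six-membered aromatic ring of carbon only, as compound 1 does, and no measured step speaks to the methylsulfonyl substituent. The account therefore expects for compound 3 a step of a number 12 percentage points lower from compound 2 to compound 3 (beyond the scatter), small and likely within the scatter, with the estimate for compound 3 in this assay being -5%, in a range from -30% to 20%.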

Compound 3, a percentage reported as inhibition, at one concentration (the size of the read-out at that concentration, not a potency): -16%
The estimate for compound 3 lay 11 percentage points above the measured number; the range from low to high includes it.
By their numbers in this assay, from the lowest: compounds 1 and 3 (each within the scatter of the next); then compound 2.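

In this assay, 3-(methylsulfonyl)phenyl in place of pyridin-2-yl on the aromatic nitrogen gives a number 23 percentage points lower from compound 2 to compound 3 (beyond the scatter) and so brings a second group with a six-membered aromatic ring of carbon only to this position. Methylsulfonyl in place of fluoro on an aromatic carbon of that ring gives a number 1 percentage points higher from compound 1 to compound 3 (within the scatter) and leaves the two substituents undistinguished in this read-out, so among these three compounds, with none going against it, only the ring with a hetero atom stands apart, on the evidence of compound 2 alone. Nothing at hand accounts for this separation.

The compounds shown leave open whether the separation belongs to pyridin-2-yl in particular or would also appear with pyridin-3-yl, pyrimidin-2-yl or an unsubstituted phenyl group on this nitrogen. They also leave open whether a substituent of another kind on the carbon-only ring, such as an amine or a carboxylic acid, would move the number in this assay away from where compound 1 and compound 3 stand.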